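The source may hold more compounds than are shown below. What is called first, only, known or untested is meant among the compounds shown, and "the series" means these compounds.

Measured so far:
Compound 1, `CNC1=C([N+](=O)[O-])C(c2ccc(N3CCN(c4ccnc5cc(Cl)ccc45)CC3)cc2)c2cc(Cl)ccc2O1`: 74500 nM
Compound 2, `CNC1=C([N+](=O)[O-])C(c2ccc(N3CCN(c4ccnc5cc(Cl)ccc45)CC3)cc2)c2cc(Cl)cc(Cl)c2O1`: 97800 nM
Compound 3, `CNC1=C([N+](=O)[O-])C(c2ccc(N3CCCN(c4ccnc5cc(Cl)ccc45)CC3)cc2)c2ccccc2O1`: 91400 nM

All three numbers come from an ADME assay on Vero cells (Chlorocebus sabaeus) for cytotoxicity, read by MTT assay, with a stated time of 72 h; a lower number here means that less compound is tolerated, a higher number that more compound is tolerated. Compound 2 differs from compound 1 by chloro in place of hydrogen on an aromatic carbon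
and the step it made was a 1.3-fold higher number from compound 1 to compound 2 (0.12 log units; within the scatter), so the two values are indistinguishable here. Compound 3 carries a different core; how its core differs from that of compound 1 is not broken down here, and the two values simply show that compound 1 and compound 3 sit within the scatter of each other, as do compound 2 and compound 3.

Compound 4, `CNC1=C([N+](=O)[O-])C(c2ccc(N3CCCN(c4ccnc5cc(Cl)ccc45)CC3)cc2)c2cc(Cl)ccc2O1`, is the not yet measured partner of compound 3 and differs from it by chloro in place of hydrogen on an aromatic carbon
This is the same kind of change as that from compound 1 to compound 2, though the surroundings differ: in the earlier pair the entering chloro sat ortho to a fused ring, meta to a chloro group and meta to a fused ring, whereas here it sits meta to a fused ring and para to a fused ring. In this assay the step from compound 3 to compound 4 is expected to be a 1.1-fold higher number from compound 3 to compound 4 (0.06 log units; within the scatter), resting on the earlier step of a 1.3-fold higher number from compound 1 to compound 2 (0.12 log units; within the scatter), which stayed within the scatter. Compound 4 is therefore estimated to give 105000 nM, with a likely range from 60000 nM to 180000 nM.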

Compound 4, half-maximal cytotoxic concentration: 77000 nM
For compound 4 the middle estimate is 1.4-fold (0.13 log units) above the measured one; the measured number falls inside the stated range.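

In this assay, chloro in place of hydrogen on an aromatic carbon gave a 1.2-fold lower number from compound 3 to compound 4 (0.07 log units; within the scatter), so on this core the change has no effect that can be told from the scatter. Set beside the earlier step, the two results do not separate, and the change looks the same on both cores: the same change on two cores in this assay, a 1.3-fold higher number (0.12 log units; within the scatter) from compound 1 to compound 2 and a 1.2-fold lower number (0.07 log units; within the scatter) from compound 3 to compound 4, 1.6-fold (0.19 log units) apart, within the scatter of two such steps This shows only that the change stayed within the scatter on the two cores shown; it does not show that a real effect carries from one core to the other, since neither step has an effect to carry, and the chloro also enters different surroundings in the two pairs.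

The compounds shown leave open whether a bromo, a methoxy or a trifluoromethyl group in place of the chloro would also stay within the scatter in this assay. They also leave open whether any such group would behave alike on both cores once a step goes beyond the scatter.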